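The source may hold more compounds than are shown below. What is called first, only, known or untested is meant among the compounds shown, and "the series" means these compounds.

Of the compounds shown here, three that share one core have been measured in a functional assay on HeLa cells (Homo sapiens) for cytotoxicity, read by MTT assay, with a stated time of 48 h, tested at 12.5 uM; on this read-out higher numbers stand for a stronger effect at the one concentration tested and lower numbers for a weaker effect. Compound 1 `CS(=O)(=O)c1ccc(Cc2n[nH]c(=S)n2/N=C/c2c(F)cccc2Cl)cc1` gives 49.8%, compound 2 `CS(=O)(=O)c1ccc(Cc2n[nH]c(=S)n2/N=C/c2ccc(-c3ccccc3)cc2)cc1` gives 30.4%, and compound 3 `CS(=O)(=O)c1ccc(Cc2n[nH]c(=S)n2/N=C/c2ccc(Cl)cc2)cc1` gives 44.7%. Among these three numbers compound 3 stands second highest; the step of a number 5.1 percentage points lower from compound 1 to compound 3 (within the scatter) lies within the scatter, while the step of a number 14.3 percentage points higher from compound 2 to compound 3 (beyond the scatter) lies beyond it.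

Compound 4 `CS(=O)(=O)c1ccc(Cc2n[nH]c(=S)n2/N=C/c2ccccc2Cl)cc1` has not yet been measured. It differs from compound 3 only in the aromatic ring on the carbon with a double bond to nitrogen: 2-chlorophenyl in place of 4-chlorophenyl on a carbon with a double bond to nitrogen. The step from compound 1 to compound 3 bears most on this change, as compound 1 carries 2-chloro-6-fluorophenyl on that same carbon, and that step stayed within the scatter. The step from compound 2 to compound 3 concerns a different group and says less here.

Compound 4 is therefore expected to land close to compound 3, with a step of a number 3.3 percentage points higher from compound 3 to compound 4 (within the scatter) that does not go beyond the scatter. The estimate for compound 4 in this assay is 48%, within a range from 36% to 60%.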

Compound 4, a percentage reported as activity, at one concentration (the size of the read-out at that concentration, not a potency): 34.7%
Beside the measured number, compound 4's estimate is 13.3 percentage points above it, outside the stated range (below it).
By their numbers in this assay, from the lowest: compounds 2, 4, 3 and 1 (each within the scatter of the next, the first and the last beyond it).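

Placing the chloro differently, with 2-chlorophenyl in place of 4-chlorophenyl on the carbon with a double bond to nitrogen, gives in this assay a change that reads as a number 10 percentage points lower from compound 3 to compound 4 (within the scatter) and so cannot be told apart from repeat variation. Among the compounds shown here, the loss of fluoro is clearer: hydrogen in place of fluoro on an aromatic carbon, with the chloro kept, gives a number 15.1 percentage points lower from compound 1 to compound 4 (beyond the scatter) and is the first step to show that this single atom on the ring can shift the number beyond the scatter. Nothing measured here accounts for either step.

The compounds shown leave open whether a ring carrying fluoro without chloro would keep the higher number. They also leave open how a methoxy group, an amine or a carboxylic acid in place of the chloro would read.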